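Removing a chloro from the aryl thiazole ketone series

The compounds below may be only part of what the source reports. "The series", "measured", "known", "first", "only" and "open" are said of these compounds alone.

Compound 1 `Cc1nc(-c2ccc(Cl)cc2)sc1C(=O)CSc1nc(-c2ccccc2)c(C#N)c(=O)[nH]1` is one of two compounds in this set measured in a functional assay on U-87MG ATCC cells for antiproliferative activity against U-87 MG (Homo sapiens), read by MTT assay, with a stated time of 48 h, tested at 50 uM (on this read-out lower numbers stand for a stronger effect and higher numbers for a weaker effect at the one concentration tested), where it gives 41.6%. Among the measured compounds shown here, compound 2 `Cc1nc(-c2ccc(Cl)cc2)sc1C(=O)CSc1nc(-c2cccc(Cl)c2)c(C#N)c(=O)[nH]1` is its only measured neighbour, and in this assay compound 2 gives 52.6%, so compound 1 stands with the lowest number of the two. For the measured compounds named here, the one step that separates them, a number 11 percentage points higher from compound 1 to compound 2 (beyond the scatter), came from chloro in place of hydrogen on an aromatic carbon of the pyrimidinone-side phenyl and made the effect weaker.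

Compound 3 `Cc1nc(-c2ccccc2)sc1C(=O)CSc1nc(-c2ccccc2)c(C#N)c(=O)[nH]1` has not yet been tested. Its difference from compound 1 is hydrogen in place of chloro on an aromatic carbon, placed on the six-membered aromatic ring attached to the thiazole, para to a large group. Going by the values given here, the only measured step concerns a chloro on a different ring, and it ran the other way, adding rather than removing chlorine, so it is a loose guide at best: taking a chloro away could leave the number roughly where compound 1 sits or move it modestly in either direction. Compound 3 is therefore expected to show 44%, within 30% to 58%, which amounts to an estimated step of a number 2.4 percentage points higher from compound 1 to compound 3 (within the scatter).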

Compound 3, a percentage reported as activity, at one concentration (the size of the read-out at that concentration, not a potency): 77.5%
Beside the measured number, compound 3's estimate is 33.5 percentage points below it; the measured number lies above the stated range.
By their numbers in this assay, from the lowest: compound 1; then compound 2; then compound 3.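

In this assay, the change from 4-chlorophenyl to phenyl gives a number 35.9 percentage points higher from compound 1 to compound 3 (beyond the scatter), a large step towards a weaker effect, so at this place, para to a large group, the chloro of compound 1 goes with a clearly stronger effect. Among the compounds shown here, the earlier compounds could not show this, since their only step concerned a chloro on the other phenyl ring, where a number 11 percentage points higher from compound 1 to compound 2 (beyond the scatter) means that adding the atom also weakened the effect. A chloro is therefore not favourable or unfavourable in itself in this pair of changes: its presence goes with a stronger effect on one ring and a weaker one on the other, and nothing available here accounts for that difference.

From the compounds shown here alone, what remains open is whether the chloro itself is needed at this place, or whether another group, such as a fluoro, a methyl, a methoxy or an amine, could stand in its place and hold the number near that of compound 1. Going by these compounds, it is also open whether the two chloro changes act independently when combined, which would take a compound with hydrogen at this place and the added chloro of compound 2 on the other ring.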